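The compounds below may be only part of what the source reports. "The series", "measured", "known", "first", "only" and "open" are said of these compounds alone.

Measured so far in a functional assay on a cell-free system (plasma, Homo sapiens), with a stated time of 3 min; a lower number here means a stronger inhibitor, a higher number a weaker inhibitor:
compound 1, `O=C(NCc1cc(Cl)ccc1-n1cnnn1)[C@@H]1[C@@H]2C[C@@H]2CN1C(=O)[C@H](O)c1ccccc1`, gives 700 nM
compound 2, `O=C(NCc1cc(Cl)ccc1-n1cnnn1)[C@@H]1[C@@H]2C[C@@H]2CN1C(=O)[C@H](O)Cc1ccccc1`, gives 970 nM
compound 3, `O=C(NCc1cc(Cl)ccc1-n1cnnn1)[C@@H]1[C@@H]2C[C@@H]2CN1C(=O)[C@H](O)c1ccccc1F`, gives 580 nM

Compound 3 shows the lowest of the three numbers, but its gaps to the other two lie within the scatter: a 1.2-fold lower number from compound 1 to compound 3 (0.08 log units; within the scatter) and a 1.7-fold lower number from compound 2 to compound 3 (0.22 log units; within the scatter). The three compounds are thus not separable in this assay.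

Compound 4, `COC(C)(C)[C@@H](O)C(=O)N1C[C@H]2C[C@H]2[C@H]1C(=O)NCc1cc(Cl)ccc1-n1cnnn1`, is not yet measured. It differs from compound 3 in one place: 1-methoxy-1-methylethyl in place of 2-fluorophenyl on a saturated chain carbon bound to a carbonyl carbon and an oxygen on a saturated carbon.

Among the compounds with values here, two measured steps bear on the same place. The exchange of phenyl for benzyl, a 1.4-fold higher number from compound 1 to compound 2 (0.14 log units; within the scatter), and the exchange of hydrogen for fluoro, a 1.2-fold lower number from compound 1 to compound 3 (0.08 log units; within the scatter), both left the number within the scatter. Within the data shown here, neither step replaces a ring with a chain; the change to 1-methoxy-1-methylethyl has no direct precedent among the three measured compounds. What the data do show is that this place tolerates phenyl, benzyl and 2-fluorophenyl without a step beyond the scatter. The step expected is a 1.9-fold higher number from compound 3 to compound 4 (0.28 log units; within the scatter), with wide uncertainty in both directions. Compound 4 is estimated at 1100 nM in this assay, with a range from 300 nM to 4000 nM.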

Compound 4, half-maximal inhibitory concentration: 1000 nM
Estimate against measurement, compound 4: 1.1-fold (0.04 log units) above; low and high end bracket the measured number.
By their numbers in this assay, from the lowest: compounds 3, 1, 2 and 4 (each within the scatter of the next).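

In this assay, the place on a saturated chain carbon bound to a carbonyl carbon and an oxygen on a saturated carbon now has a measured group with no ring: 1-methoxy-1-methylethyl in place of 2-fluorophenyl gives a 1.7-fold higher number from compound 3 to compound 4 (0.24 log units; within the scatter) while in place of benzyl it gives a 1.0-fold higher number from compound 2 to compound 4 (0.01 log units; within the scatter) and in place of phenyl it gives a 1.4-fold higher number from compound 1 to compound 4 (0.15 log units; within the scatter) as the third step. Among these four compounds, a six-membered aromatic ring of carbon only is therefore not needed at this place to keep the number within the scatter of the ring-bearing compound 1, compound 2 and compound 3, which the earlier comparisons, all made among groups carrying such a ring, could not show. No measured information bears on why this exchange leaves the number within the scatter.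

Within the data shown here, no step at this place yet goes beyond the scatter. The compounds shown do not reveal which kinds of group this place would fail to tolerate, such as an amine, a carboxylic acid or a longer chain. They also leave open whether the ether oxygen of 1-methoxy-1-methylethyl matters, which a comparison with the all-carbon tert-butyl group would address.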